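The source may report more compounds than this note shows. Statements on the series, on what has been measured and on what is new or still open speak of the compounds shown alone.

Compound 1, `COc1ccc2nccc(C3CN(CC4CCCN(Cc5cc6ccccc6[nH]5)C4)C(=O)O3)c2c1` — < 50200 nM in an in vitro functional assay on RBL cells for antagonist activity at C-C chemokine receptor type 8 (Homo sapiens), read by FLIPR and calcium flux (a lower number here means a stronger inhibitor, a higher number a weaker inhibitor), which is a limit of the assay rather than a number.
Compound 2, `COc1ccc2nccc(C3CN(C4CCCCN(Cc5cc6ccccc6[nH]5)C4)C(=O)O3)c2c1` — < 50200 nM in this assay, likewise a limit and not a number.
Compound 3, `COc1ccc2nccc(C3CN(C4CCN(Cc5ccc6ccccc6c5)CC4)C(=O)O3)c2c1` — 1260 nM in this assay.

Among the measured compounds shown here, of the three values, compound 3 carries the only one that is a number. The other two rest at the limit of < 50200 nM in this assay, at which 2 of the 3 values shown sit, so nothing can be said about the order of compound 1 and compound 2 relative to compound 3 beyond the fact that each of them is a limit. For the measured compounds named here, no pair among the measured compounds differs in a single place, so no measured step exists to lean on.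

Compound 4, `COc1ccc2nccc(C3CN(C4CCN(CCCc5ccccc5)CC4)C(=O)O3)c2c1`, is not yet measured. It differs from compound 3 by phenethyl in place of naphthalen-2-yl on a saturated chain carbon bound to an amine nitrogen in a ring. With the fused ring gone and an open chain in its place, the expectation is a modest loss in this assay, a step from compound 3 to compound 4 of about a 2.4-fold higher number from compound 3 to compound 4 (0.38 log units; beyond the scatter), which is at the edge of the scatter rather than clearly beyond it. Compound 4 is therefore estimated at 3000 nM, with a range from 800 nM to 15000 nM.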

Compound 4, half-maximal inhibitory concentration: 251 nM
The estimate for compound 4 lay 12-fold (1.08 log units) above the measured number, and the stated range ends above it.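

In this assay, among the compounds shown here, putting phenethyl in place of naphthalen-2-yl on a saturated chain carbon bound to an amine nitrogen in a ring gives a 5.0-fold lower number from compound 3 to compound 4 (0.70 log units; beyond the scatter), the first step in this set that can be read between two numbers. It shows that the second aromatic ring of naphthalen-2-yl is not required at this position: one six-membered aromatic ring of carbon, carried on an open chain and read one bond further out as 3-phenylpropyl in place of (naphthalen-2-yl)methyl, gives the stronger inhibitor of this pair, with fewer heavy atoms. Nothing shown here gives a cause for this step.

Because ring count and chain length changed together, the compounds shown leave open which of the two carries the step, a question that a benzyl group, a longer chain such as 4-phenylbutyl, or a 2-(naphthalen-2-yl)ethyl group on the same nitrogen would bear on. Going by these compounds, whether an amine or a carboxylic acid on the phenyl ring of compound 4 would be tolerated also remains open.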